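The source may hold more compounds than are shown below. What is called first, only, known or untested is meant among the compounds shown, and "the series" means these compounds.

In a functional assay on the whole organism with Canis familiaris (Canis lupus familiaris) as the target, at a dose of 5 mg/kg by the intravenous route (a higher number here means a stronger effect of the compound at the dose given, a lower number a weaker effect), compound 1 `CC(=O)Nc1c(C)nc2c(CCc3ccccc3)cccn12` gives 3%. Compound 2 `Cc1nc2c(OCc3ccccc3)cccn2c1NC(C)C` gives 0% in this assay, and the two numbers lie within the usual scatter of each other, so compound 1 stands level with compound 2 rather than apart from it; neither is told from the other by these data. Within the data shown here, no step between measured compounds that differ in one place is available here, so nothing measured shows how far a single change moves this read-out. Compound 3 `CSc1c(C)nc2c(CCc3ccccc3)cccn12` has yet to be measured; it differs from compound 1 by methylsulfanyl in place of acetamido on an aromatic carbon. Both measured numbers sit close to no effect, and nothing in them points upward. The step expected is a number 2 percentage points higher from compound 1 to compound 3 (within the scatter), none beyond the scatter. Compound 3 is estimated at 5%, with a range from 0% to 20%.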

Compound 3, a percentage reported as inhibition, in the whole organism at one dose (the size of the read-out at that dose, not a potency): 0%
Beside the measured number, compound 3's estimate is 5 percentage points above it, within the range that was stated.
By their numbers in this assay, from the lowest: compounds 2, 3 and 1 (each within the scatter of the next).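

Methylsulfanyl in place of acetamido on an aromatic carbon, next to the ring nitrogen, is the first single-place change that can be read in this series: in this assay it gives a number 3 percentage points lower from compound 1 to compound 3 (within the scatter). Taking away the hydrogen-bond donor of acetamido therefore does not separate the two compounds at this dose, and both stay close to no effect. No measured evidence bears on why these two compounds read alike.

Still open, on these data alone, is whether any group at this position can move the read-out beyond the scatter, for example a primary amine, a carboxylic acid or a longer chain such as butylsulfanyl. Also open, as far as these compounds go, is whether compound 1 and compound 3 remain indistinguishable at another dose.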